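Compound 3 to compound 4: a saturated ring enters

This account rests on a few compounds, and the source may have more. Where it says the series, first, only, none or still open, it means among the compounds named here.

Three compounds have been measured in a functional assay on MCF7 cells (Homo sapiens) for cytotoxicity, read by WST assay, with a stated time of 72 h (a higher number here means a weaker inhibitor, a lower number a stronger inhibitor), so far:
- compound 1 `O=C1Nc2c(ccc(F)c2F)C1(c1ccc(O)cc1)c1ccc(F)cc1` gives 2.6 nM
- compound 2 `O=C1Nc2c(ccc(F)c2F)C1(c1ccncc1)c1ccc(O)cc1` gives 37 nM
- compound 3 `CCCC1(c2ccc(O)cc2)C(=O)Nc2c1ccc(F)c2F` gives > 1000 nM

Compound 3 stands at > 1000 nM as a limit of the assay and not a number. The other two compounds lie well to the stronger side, as shown by an at least 380-fold higher number from compound 1 to compound 3 (2.58 log units; beyond the scatter) and by an at least 27-fold higher number from compound 2 to compound 3 (1.43 log units; beyond the scatter), both large steps.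

The next compound is compound 4 `O=C1Nc2c(ccc(F)c2F)C1(CC1CCCCC1)c1ccc(O)cc1`, and the change is cyclohexyl in place of ethyl on a saturated chain carbon bound to a saturated ring carbon, which reads as cyclohexyl in place of ethyl on a saturated chain carbon bound to a saturated ring carbon, or as propyl to cyclohexylmethyl. For the measured compounds named here, no measured step makes this exact change. The nearest evidence is that compound 3, with propyl in place of a ring, shows an at least 27-fold higher number from compound 2 to compound 3 (1.43 log units; beyond the scatter) as its smaller known loss. Which ring is present also matters, as a 14-fold higher number from compound 1 to compound 2 (1.15 log units; beyond the scatter) shows. A lower number is therefore expected in this assay, though only a moderate step, and another limit remains possible. The expected step is an at least 3.3-fold lower number from compound 3 to compound 4 (0.52 log units; beyond the scatter) in this estimate. Compound 4 is estimated at 300 nM, with an expected range from 50 nM to 1800 nM as its span.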

Compound 4, half-maximal inhibitory concentration: 102 nM
Estimate against measurement, compound 4: 2.9-fold (0.47 log units) above, within the range that was stated.
By their numbers in this assay, from the lowest: compound 1; then compound 2; then compound 4. At a limit, above all of these: compound 3.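

In this assay, a saturated ring carried on a chain at this position restores much of the activity missing from the propyl compound, with cyclohexyl in place of ethyl giving an at least 9.8-fold lower number from compound 3 to compound 4 (0.99 log units; beyond the scatter), so an aromatic ring directly on the saturated ring carbon is not required for activity in the nanomolar range. As far as these compounds go, compound 3 remains a limit of the assay and not a number, so the full size of that step stays unknown: the limit of > 1000 nM in this assay, at which 1 of the 4 values shown sits. Cyclohexylmethyl still does not match either aromatic group, falling modestly short of pyridin-4-yl in a 2.8-fold higher number from compound 2 to compound 4 (0.44 log units; beyond the scatter) and much further short of 4-fluorophenyl in a 39-fold higher number from compound 1 to compound 4 (1.59 log units; beyond the scatter).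

The compounds shown leave open whether the ring itself matters, or whether an open chain such as hexyl would serve as well as cyclohexylmethyl. Also open, from the compounds shown here alone, is how cyclohexyl would behave set directly on the saturated ring carbon, without the intervening chain carbon.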